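Removing a trifluoromethyl from a weakly toxic amide

A few compounds are considered here, and "the series" means these few. Any claim that something is new, unique, unknown or untested is made for them only; others in the source may bear on it.

Of the compounds shown here, three sharing a pyrazole-based core have been tested in a functional assay on SK-MEL-5 cells (Homo sapiens) for inhibition, read by sulforhodamine B assay, with a stated time of 48 h; on this read-out lower numbers stand for higher toxicity in this test and higher numbers for lower toxicity in this test. Compound 1 `O=C(Nc1cccc(-n2cc(-c3ccncc3)c(-c3ccc(Cl)c(O)c3)n2)c1)Nc1ccc(Cl)c(Cl)c1` gives 2350 nM, and compound 3 `O=C(Nc1cccc(-n2cc(-c3ccncc3)c(-c3ccc(Cl)c(O)c3)n2)c1)Nc1cc(C(F)(F)F)cc(C(F)(F)F)c1` gives 2620 nM. Compound 2 `COc1cc(-c2nn(-c3cccc(NC(=O)c4cccc(C(F)(F)F)c4)c3)cc2-c2ccncc2)ccc1Cl`, which carries an amide rather than a urea, gives 40600 nM, the highest of the three numbers and beyond the scatter from both others. Compound 4 `COc1cc(-c2nn(-c3cccc(NC(=O)c4ccccc4)c3)cc2-c2ccncc2)ccc1Cl` differs from compound 2 by one change: hydrogen in place of trifluoromethyl on an aromatic carbon. Going by the values given here, no measured pair isolates this change, so its effect is unknown. The account expects a modest step in this assay, most likely toward a higher number or none beyond the scatter, since the cap is already the weakly toxic part. Compound 4 is therefore estimated at 55000 nM, within 20000 nM to 150000 nM, a step of a 1.4-fold higher number from compound 2 to compound 4 (0.13 log units; within the scatter).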

Compound 4, concentration lethal to 50% of the cells: 7100 nM
For compound 4 the middle estimate is 7.7-fold (0.89 log units) above the measured one, and the stated range ends above it.
By their numbers in this assay, from the lowest: compounds 1 and 3 (each within the scatter of the next); then compound 4; then compound 2.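

Going by these compounds alone, the first pair to isolate this position shows that the substituent on the benzoyl ring matters in this test: hydrogen in place of trifluoromethyl gives a 5.7-fold lower number from compound 2 to compound 4 (0.76 log units; beyond the scatter). The step runs toward higher toxicity in this assay, so trifluoromethyl at this position goes with the weaker toxicity of these two amides. No measurement shown here accounts for this direction.

Going by these compounds, it remains open how an amine or a carboxylic acid on this aromatic carbon would compare with hydrogen and trifluoromethyl. On these data alone, whether the same change would move the urea compounds in the same direction also remains open.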